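A few compounds are considered here, and "the series" means these few. Any claim that something is new, unique, unknown or untested is made for them only; others in the source may bear on it.

Of the compounds shown here, two built on a shared core have been tested in an assay on CHO cells for displacement of a labelled ligand from adenosine receptor A2b (Homo sapiens), read by scintillation counting, with a stated time of 75 min, in the presence of a further agent that is not named here; on this read-out higher numbers stand for weaker inhibition and lower numbers for stronger inhibition. Compound 1 `CCCn1c(=O)[nH]c2nc(-c3ccc(S(=O)(=O)N4CCN(c5ccccc5)C(C)C4)cc3)[nH]c2c1=O` gives 7.15 nM in this assay, while compound 2 `CCCn1c(=O)[nH]c2nc(-c3ccc(S(=O)(=O)N4CCN(c5ccc(I)cc5)CC4)cc3)[nH]c2c1=O` gives 0.159 nM, the lowest of the two numbers; the gap to compound 1 lies beyond the scatter, so compound 2 is the stronger inhibitor of the pair. Compound 3 `CCCn1c(=O)[nH]c2nc(-c3ccc(S(=O)(=O)N4CCN(Cc5ccc(Br)c(F)c5)CC4)cc3)[nH]c2c1=O` has not yet been measured. It differs from compound 2 in a single place: 4-bromo-3-fluorobenzyl in place of 4-iodophenyl on an amine nitrogen in a ring. Going by the values given here, no measured pair shows what such a change does in this assay, so the expectation rests on compound 2 alone. Because compound 2 gives 0.159 nM, a number already very low for a measurement of this kind, the change is expected to bring a moderate rise, and the expected step of a 7.5-fold higher number from compound 2 to compound 3 (0.88 log units; beyond the scatter) points toward weaker inhibition. Compound 3 is therefore estimated at 1.2 nM, with a range from 0.2 nM to 7 nM.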

Compound 3, inhibition constant: 0.473 nM
Beside the measured number, compound 3's estimate is 2.5-fold (0.40 log units) above it; the measured number falls inside the stated range.
By their numbers in this assay, from the lowest: compound 2; then compound 3; then compound 1.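

With this change, the amine nitrogen in the six-membered ring has its first measured step in this assay: 4-bromo-3-fluorobenzyl in place of 4-iodophenyl gives a 3.0-fold higher number from compound 2 to compound 3 (0.47 log units; beyond the scatter), which is a modest change. Even after this swap, compound 3 gives 0.473 nM, so a low number at this position does not depend on the 4-iodophenyl group. No available evidence explains the rise.

This single swap changes the halogens and adds the benzyl link together, so the compounds shown cannot say how much of the step comes from each change. A 4-iodobenzyl or 4-bromophenyl group would separate the two, while a group carrying an amine or a carboxylic acid would test whether this position also accepts something other than a halogenated aromatic ring.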